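Replacing an aryl ether by a chlorophenyl on the shared core

A few compounds are considered here, and "the series" means these few. Any claim that something is new, unique, unknown or untested is made for them only; others in the source may bear on it.

Of the compounds shown here, three built on one core have been measured in a functional assay on CHO cells for agonist activity at Free fatty acid receptor 1 (Homo sapiens), read by FLIPR and calcium flux, tested at 1 uM; on this read-out lower numbers stand for an effect already at smaller amounts and higher numbers for an effect only at larger amounts of compound. Compound 1 `Cc1ccc(OCc2nnc(C(=O)Nc3ccc(CCC(=O)O)cc3)s2)c(C)c1` gives 2540 nM, compound 2 `Cc1ccc(OCc2nnc(C(=O)Nc3ccc(CCC(=O)O)cc3)s2)cc1` gives 2170 nM, and compound 3 `COc1ccc(OCc2nnc(C(=O)Nc3ccc(CCC(=O)O)cc3)s2)cc1` gives 2430 nM. The steps among them are all small: a 1.2-fold lower number from compound 1 to compound 2 (0.07 log units; within the scatter), a 1.0-fold lower number from compound 1 to compound 3 (0.02 log units; within the scatter) and a 1.1-fold higher number from compound 2 to compound 3 (0.05 log units; within the scatter). Compound 3 therefore stands second highest of the three, with every number within the scatter of the others. Compound 4 `O=C(O)CCc1ccc(NC(=O)c2nnc(Cc3cccc(Cl)c3)s2)cc1` differs from compound 3 by 3-chlorophenyl in place of 4-methoxyphenoxy on a saturated chain carbon bound to an aromatic carbon. Within the data shown here, only a 1.0-fold lower number from compound 1 to compound 3 (0.02 log units; within the scatter) touches the same part of the molecule, and it stayed within the scatter; no measured step removes the linking oxygen, so the estimate carries a wide range. The expected step is a 1.0-fold higher number from compound 3 to compound 4 (0.01 log units; within the scatter). Compound 4 is estimated at 2500 nM, between 800 nM and 8000 nM.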

Compound 4, half-maximal effective concentration: 2390 nM
Compound 4: middle estimate off by 1.0-fold (0.02 log units), on the high side; the range from low to high includes it.
By their numbers in this assay, from the lowest: compounds 2, 4, 3 and 1 (each within the scatter of the next).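

In this assay, 3-chlorophenyl in place of the aryl ethers removes the linking oxygen, yet all three new steps stay within the scatter (a 1.0-fold lower number from compound 3 to compound 4 (0.01 log units; within the scatter)) (a 1.1-fold higher number from compound 2 to compound 4 (0.04 log units; within the scatter)) (a 1.1-fold lower number from compound 1 to compound 4 (0.03 log units; within the scatter)). At this saturated chain carbon, then, the read-out does not separate a group with the oxygen from one without it. Nothing given here offers a reason for this. On these data alone, all four compounds carry a six-membered aromatic ring at this place, so what an amine or a longer chain would do there stays open.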